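The compounds below may be only part of what the source reports. "The series", "measured", "known", "first", "only" and "open" are said of these compounds alone.

Among the compounds with values here, in an ADME assay on the whole organism for inhibition, with Echinochloa crus-galli var. formosensis as the target (on this read-out higher numbers stand for weaker inhibition and lower numbers for stronger inhibition), compound 3 `CCNc1nc(Cl)nc(N[C@H](C)c2ccccc2)n1` reads 174 nM, the second highest of the three numbers so far. Compound 2 `CCNc1nc(Cl)nc(N[C@@H](C)c2ccccc2)n1` gives 17.4 nM and compound 1 `CCN(CC)c1nc(Cl)nc(NC(C)c2ccccc2)n1` gives 17800 nM. The next case is compound 4 `CCNc1nc(Cl)nc(NC(C)c2ccccc2)n1`: the two compounds have the same atoms and bonds; at least one stereo element is drawn with a configuration in one of them and without one in the other: 1 of 1 stereo elements differ; a stereocentre at a saturated chain carbon is drawn R in compound 3 and without a configuration in compound 4. Within the data shown here, the one measured step bearing on this is a 10-fold higher number from compound 2 to compound 3 (1.00 log units; beyond the scatter), which is modest and traces to the fact that compounds 2 and 3 differ only in the configuration as drawn. With the stereocentre drawn without a configuration, the number in this assay is expected to lie between those of compound 2 and compound 3, so a step smaller than that one, towards a lower number, is expected. The expected step is a 5.0-fold lower number from compound 3 to compound 4 (0.70 log units; beyond the scatter). For compound 4 the estimate is 35 nM, with an expected range of 15 nM to 95 nM.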

Compound 4, half-maximal inhibitory concentration: 43.7 nM
Compound 4: middle estimate off by 1.2-fold (0.10 log units), on the low side; the measured number falls inside the stated range.
By their numbers in this assay, from the lowest: compound 2; then compound 4; then compound 3; then compound 1.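

In this assay, the form without a drawn configuration falls inside the gap left by the two drawn forms: a 4.0-fold lower number from compound 3 to compound 4 (0.60 log units; beyond the scatter), and a 2.5-fold higher number from compound 2 to compound 4 (0.40 log units; beyond the scatter). Compound 2, drawn S, therefore keeps the lowest number at this stereocentre. Compound 4 is also the first partner for compound 1 that differs in one place, and hydrogen in place of ethyl on a nitrogen on an aromatic ring gives a 410-fold lower number from compound 1 to compound 4 (2.61 log units; beyond the scatter), far larger than either stereocentre step.

Going by these compounds, whether that nitrogen step holds with the stereocentre drawn S or R remains open. So does the effect of a methyl or propyl group on that nitrogen.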